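Working notes: the step from compound 2 to compound 3

A few compounds are considered here, and "the series" means these few. Any claim that something is new, unique, unknown or untested is made for them only; others in the source may bear on it.

Compound 1 `O=c1cc(Cn2cc(CCc3ccccc3)nn2)c2ccc(O)cc2o1` in a functional assay on CFPAC-1 cells (Homo sapiens) for inhibition, read by MTT assay, with a stated time of 72 h (a lower number here means a stronger inhibitor, a higher number a weaker inhibitor), gives only a limit, > 100000 nM. Among the compounds with values here, compound 2 `O=c1cc(Cn2cc(-c3ccc(Br)cc3)nn2)c2ccc(O)cc2o1` in this assay gives 52900 nM, the only number so far. Within the data shown here, the one other value is a limit, (the limit of > 100000 nM in this assay, at which 1 of the 2 values shown sits), belonging to compound 1. The step of an at least 1.8-fold lower number from compound 1 to compound 2 (0.27 log units; that floor lies within the scatter) exchanges the whole arm and does not test the present change. Compound 3 `CCCC1CCC(c2ccc(-c3cn(Cc4cc(=O)oc5cc(O)ccc45)nn3)cc2)CC1` differs from compound 2 by 4-propylcyclohexyl in place of bromo on an aromatic carbon. Among the measured compounds shown here, no measured step bears on this exchange, so no shift beyond the scatter is expected. Compound 3 is therefore estimated at 40000 nM, within 8000 nM to 150000 nM. The expected step is a 1.3-fold lower number from compound 2 to compound 3 (0.12 log units; within the scatter).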

Compound 3, half-maximal inhibitory concentration: 52800 nM
The estimate for compound 3 lay 1.3-fold (0.12 log units) below the measured number; low and high end bracket the measured number.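

The exchange of bromo for 4-propylcyclohexyl on an aromatic carbon gives, in this assay, a 1.0-fold lower number from compound 2 to compound 3 (0.00 log units; within the scatter). Within the data shown here, this is the first reading of this place alone, and it shows that 9 heavy atoms with a six-membered non-aromatic ring can replace a single bromine with no shift beyond the scatter. No measured evidence shown here accounts for this result.

Still open, going by these compounds, is whether an amine or a carboxylic acid at this place would give a step beyond the scatter. Also open, on these data alone, is whether any group here would do so.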